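This account rests on a few compounds, and the source may have more. Where it says the series, first, only, none or still open, it means among the compounds named here.

In a functional assay on NCI-H460 cells (Homo sapiens) for cytotoxicity, read by MTT assay, with a stated time of 68 h (a higher number here means a weaker inhibitor, a lower number a stronger inhibitor), compound 2 `O=C(Nc1cccc(-c2cccc(NC(=O)C(Cl)Cl)c2)c1)C(Cl)Cl` gives > 50000 nM, which is a limit of the assay rather than a measured number. Compound 1 `O=C(Nc1cccc(-c2ccsc2)c1)C(Cl)Cl` likewise gives > 50000 nM, again a limit. Going by the values given here, compound 3 `O=C(Nc1cccc(-c2ccoc2)c1)C(Cl)Cl` gives 37600 nM, the one numeric value among the three. Among the compounds with values here, the single measured change, an at least 1.3-fold lower number from compound 1 to compound 3 (0.12 log units; that floor lies within the scatter), lies elsewhere in the molecule and does not bear on the change now in view. Compound 4 `O=C(Nc1cccc(-c2cccc(F)c2)c1)C(Cl)Cl` differs from compound 2 by fluoro in place of ((dichloromethyl)carbonyl)amino on an aromatic carbon. Within the data shown here, no measured step touches this change, so the step of a number no higher from compound 2 to compound 4 (the limit leaves the size open) is expected to be small or absent, with the number likely staying at the limit of > 50000 nM in this assay, at which 2 of the 3 values shown sit. Compound 4 is therefore estimated at 50000 nM, within 15000 nM to 150000 nM.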

Compound 4, half-maximal inhibitory concentration: > 50000 nM
Compound 4: no number, only a limit; the forecaster's own chance of this, stated with the estimate: 60%; the middle value lies on the limit itself.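

In this assay, compound 2 and compound 4 each give only a limit, so no step can be read between them. The compounds shown leave open whether fluoro in place of ((dichloromethyl)carbonyl)amino changes the number at all.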